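The compounds below may be only part of what the source reports. "The series", "measured", "known", "first", "only" and "open" are said of these compounds alone.

Measured so far:
- compound 1, `Cc1c(-c2cc(Cl)cc(Cl)c2)c(C(=O)O)nn1-c1nc(-c2cccnc2)c(SC(C)C)s1`: "not active" (no number reported)
- compound 2, `Cc1nn(-c2nc(-c3ccc(Cl)c(Cl)c3)c(SC(C)C)s2)c(C(=O)O)c1-c1cccc(C(F)(F)F)c1`: 22000 nM
- compound 3, `Cc1nn(-c2nc(-c3ccc(Cl)c(Cl)c3)c(SC(C)C)s2)c(C(=O)O)c1-c1cc(C(F)(F)F)cc(C(F)(F)F)c1`: 1800 nM

In a functional assay on BJAB cells (Homo sapiens) for antiproliferative activity, with a stated time of 4 days (a higher number here means that more compound is needed for the effect, a lower number that less compound is needed), compound 2 gives 22000 nM, the highest of the two numbers obtained; compound 3 gives 1800 nM, and compound 1 gives no number, being recorded as not active. Within the data shown here, the only step between measured compounds is a 12-fold lower number from compound 2 to compound 3 (1.09 log units; beyond the scatter), a large step beyond the scatter.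

Compound 4, `COc1ccc(C)cc1-c1c(C)nn(-c2nc(-c3ccc(Cl)c(Cl)c3)c(SC(C)C)s2)c1C(=O)O`, differs from compound 2 as follows: 2-methoxy-5-methylphenyl in place of 3-(trifluoromethyl)phenyl on an aromatic carbon. Among the measured compounds shown here, no measured step bears on this exchange; the step to compound 3 concerns a second trifluoromethyl on the same ring, not its removal or a methoxy and methyl in its place. For the measured compounds named here, with no comparable step, no change beyond the scatter is expected, and the estimate for compound 4 is 30000 nM (range 8000 nM to 110000 nM), so the expected step is a 1.4-fold higher number from compound 2 to compound 4 (0.13 log units; within the scatter).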

Compound 4, half-maximal effective concentration: 9500 nM
Beside the measured number, compound 4's estimate is 3.2-fold (0.50 log units) above it; measured number inside the range.
By their numbers in this assay, from the lowest: compound 3; then compound 4; then compound 2.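

In this assay, 2-methoxy-5-methylphenyl in place of 3-(trifluoromethyl)phenyl gives a 2.3-fold lower number from compound 2 to compound 4 (0.36 log units; beyond the scatter) on this aromatic carbon of the five-membered ring. A trifluoromethyl group is therefore not required here for activity in this range, and a ring bearing a methoxy and a methyl group is accepted. No available evidence accounts for this shift.

From the compounds shown here alone, the separate contributions of the methoxy and methyl groups remain open, as the two enter together. Also open, going by these compounds, is how an amine or a nitrile on this ring would compare.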